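This account rests on a few compounds, and the source may have more. Where it says the series, first, only, none or still open, it means among the compounds named here.

Measured so far in a functional assay on HT cells (Homo sapiens) for antiproliferative activity, read by fluorescence, with a stated time of 72 h; on this read-out lower numbers stand for stronger inhibition of growth and higher numbers for weaker inhibition of growth:

- compound 1, `CC(C)c1n[nH]c2c(NCc3ccc(-c4ccccn4)cc3)nc(SCC(N)CN)nc12`, gives 480 nM
- compound 2, `CC(C)c1n[nH]c2c(NCc3ccc(-c4ccccn4)cc3)nc(SCCn3ccnc3)nc12`, gives 155 nM
- compound 3, `CC(C)c1n[nH]c2c(NCc3ccc(-c4ccccn4)cc3)nc(SC(CO)C(C)C)nc12`, gives 980 nM

Compound 3 stands highest of the three numbers in this assay: its nearest neighbour is compound 1, with a 2.0-fold higher number from compound 1 to compound 3 (0.31 log units; beyond the scatter), and its furthest is compound 2, with a 6.3-fold higher number from compound 2 to compound 3 (0.80 log units; beyond the scatter). The next compound, compound 4, `CC(C)c1n[nH]c2c(NCc3ccc(-c4ccccn4)cc3)nc(SCC(C)(C)N)nc12`, is not yet measured; it differs from compound 3 by 2-amino-2-methylpropyl in place of 1-(hydroxymethyl)-2-methylpropyl on a sulfur.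

Among the measured compounds shown here, the step that bears most on this is the one from compound 1 to compound 3, where a chain carrying amine groups gave way to the hydroxymethyl-bearing chain, with a 2.0-fold higher number from compound 1 to compound 3 (0.31 log units; beyond the scatter). Compound 4 returns an amine to the chain on the sulfur, so the reverse of that move is the best guide, though the two amine-bearing chains are not the same. The step from compound 2 to compound 3, a 6.3-fold higher number from compound 2 to compound 3 (0.80 log units; beyond the scatter), involves a ring and is less directly comparable. A modest move in this assay toward a lower number is therefore expected for compound 4, roughly a 2.2-fold lower number from compound 3 to compound 4 (0.34 log units; beyond the scatter), landing it near compound 1.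

Compound 4 is estimated at 450 nM, within 200 nM to 1000 nM.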

Compound 4, concentration for 50% growth inhibition: 85 nM
The estimate for compound 4 lay 5.3-fold (0.72 log units) above the measured number, and the stated range ends above it.
By their numbers in this assay, from the lowest: compounds 4 and 2 (each within the scatter of the next); then compound 1; then compound 3.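

Amine-bearing chains on the sulfur are not interchangeable in this assay: the 2-amino-2-methylpropyl chain of compound 4 reads well under the 2,3-diaminopropyl chain of compound 1 (a 5.6-fold lower number from compound 1 to compound 4 (0.75 log units; beyond the scatter)), so the large step from the 1-(hydroxymethyl)-2-methylpropyl chain (a 12-fold lower number from compound 3 to compound 4 (1.06 log units; beyond the scatter)) cannot be credited to the presence of an amine alone. A chain without a ring also reads level with the 2-(1H-imidazol-1-yl)ethyl chain of compound 2 (a 1.8-fold lower number from compound 2 to compound 4 (0.26 log units; within the scatter)), so a ring on this chain is not required for a number in this range. Nothing available accounts for the size of these steps.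

Open, going by these compounds, is what a plain 2-aminoethyl chain on the sulfur would give, a reading that would separate the amine from the two methyl groups of compound 4. Equally open, on these data alone, is the result for a longer chain such as 3-aminopropyl, or for a carboxylic acid in place of the amine.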